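This account rests on a few compounds, and the source may have more. Where it says the series, first, only, none or still open, it means among the compounds named here.

In a functional assay on CCRF-CEM cells (Homo sapiens) for cytotoxicity, read by MTT assay, with a stated time of 72 h (on this read-out higher numbers stand for weaker inhibition and lower numbers for stronger inhibition), compound 1 `O=C(/C=C/c1cccc([N+](=O)[O-])c1)c1ccc2ccccc2c1` gives 4000 nM. Exchanging its nitro group for a chloro group on the same aromatic carbon produced a 1.5-fold higher number from compound 1 to compound 2 (0.18 log units; within the scatter). In this assay, going by the values given here, compound 2 `O=C(/C=C/c1cccc(Cl)c1)c1ccc2ccccc2c1` gives 6000 nM, and the only other number, that of compound 1, lies within the usual scatter of it, so the two cannot be told apart.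

Compound 3 `O=C(/C=C/c1ccccc1)c1ccc2ccccc2c1` differs from compound 2 by hydrogen in place of chloro on an aromatic carbon, meta to a large group; seen one bond further out, a 3-chlorophenyl becomes a phenyl. Among the compounds with values here, the only measured step touching this position is the one from the nitro to the chloro group, and it stayed within the scatter. On that basis compound 3 is expected to land near 6000 nM, in a range from 2500 nM to 15000 nM. The expected step is no change at the digits printed from compound 2 to compound 3 (within the scatter), nothing beyond the scatter.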

Compound 3, half-maximal inhibitory concentration: 5000 nM
Beside the measured number, compound 3's estimate is 1.2-fold (0.08 log units) above it; the range from low to high includes it.
By their numbers in this assay, from the lowest: compounds 1, 3 and 2 (each within the scatter of the next).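

Going by these compounds alone, compound 3 adds what the earlier compounds lacked: a reference with no substituent at this place on the ring, only hydrogen. In this assay, replacing the chloro group with hydrogen gives a 1.2-fold lower number from compound 2 to compound 3 (0.08 log units; within the scatter) and replacing the nitro group with hydrogen gives a 1.3-fold higher number from compound 1 to compound 3 (0.10 log units; within the scatter), so neither group can be told apart from hydrogen here, and the chloro and nitro compounds show no measurable gain or loss over the unsubstituted phenyl. Nothing available offers an explanation for this result.

Whether any group at this place can move the number beyond the scatter stays open, since an amine, a carboxylic acid or a longer chain might behave differently from the three shown. These compounds also say nothing about changes to the shared core.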